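Swapping a ring-bearing group for hydroxy on compound 3

The source may report more compounds than this note shows. Statements on the series, on what has been measured and on what is new or still open speak of the compounds shown alone.

In a functional assay on RPMI-8226 cells (Homo sapiens) for cytotoxicity, read by MTT assay, with a stated time of 72 h (on this read-out lower numbers stand for stronger inhibition and higher numbers for weaker inhibition), compound 3 `Cc1c(C)c2c(c(C)c1OC(=O)CCC(=O)NC1CC(C)(C)N([O])C1(C)C)CCC(C)(C(=O)NC1CC(C)(C)N([O])C1(C)C)O2` gives > 300000 nM, which is a limit of the assay and not a number. Compound 4 `Cc1c(C)c2c(c(C)c1OC(=O)CCC(=O)O)CCC(C)(C(=O)NC1CC(C)(C)N([O])C1(C)C)O2` differs from it by one oxygen atom in place of a group of 11 heavy atoms (8 carbon, 2 nitrogen, 1 oxygen; one five-membered non-aromatic ring with 1 hetero atom), on a carbonyl carbon, so a hydroxy now stands on that carbonyl carbon.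

One measured step resembles this swap. Compound 1 `Cc1c(C)c2c(c(C)c1OC(=O)CCC(=O)O)CCC(C)(C(=O)NCC1CC(C)(C)N([O])C1(C)C)O2` gives > 300000 nM, which is also a limit. Compound 2 `Cc1c(C)c2c(c(C)c1OC(=O)CCC(=O)O)CCC(C)(C(=O)O)O2` gives 63000 nM. Together these make an at least 4.7-fold lower number from compound 1 to compound 2 (0.67 log units; beyond the scatter), and compound 2 has no five-membered ring group left, while compound 4 still has one. Since compound 1 keeps such a group and still gives > 300000 nM, a limit, compound 4 is expected to stay close to that limit rather than reach the level of compound 2. The expected change is small, estimated as an at least 1.3-fold lower number from compound 3 to compound 4 (0.13 log units; that floor lies within the scatter). The estimate for compound 4 is 220000 nM, with an expected range from 90000 nM to 500000 nM.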

Compound 4, half-maximal inhibitory concentration: > 300000 nM
Compound 4: only a limit was reported; the forecaster's own chance of this, stated with the estimate: 65%; middle value at least 1.3-fold (0.13 log units) away from the limit.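

In this assay, a group of 11 heavy atoms in place of one oxygen atom, on a carbonyl carbon, gives an at least 4.7-fold higher number from compound 2 to compound 4 (0.67 log units; beyond the scatter), so this shorter-linked ring-bearing group takes the value up to the limit just as the group in compound 1 does. The steps from compound 3 to compound 4 and from compound 1 to compound 4 cannot be read, as both ends of each are limits. Compound 1, compound 3 and compound 4 each carry at least one five-membered ring group and all stop at the same limit of the assay: the limit of > 300000 nM in this assay, at which 3 of the 4 values shown sit.

From the compounds shown here alone, how compound 1, compound 3 and compound 4 truly rank against one another stays open. Going by these compounds, it is also open whether a plain amine or a longer chain on that carbonyl carbon would give a readable value.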